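Adding a third methoxy group: expectation for compound 4

The compounds below may be only part of what the source reports. "The series", "measured", "known", "first", "only" and "open" are said of these compounds alone.

Compound 1 `Cc1cc(O)c(C2=NN(c3ccc(S(N)(=O)=O)cc3)C(c3ccccc3O)C2)cc1Cl` and compound 2 `Cc1cc(O)c(C2=NN(c3ccc(S(N)(=O)=O)cc3)C(c3ccccc3Cl)C2)cc1Cl` share the core and differ only at the aryl on the saturated ring carbon. In a functional assay on TK-10 cells (Homo sapiens) for antiproliferative activity, with a stated time of 48 h (on this read-out higher numbers stand for lower toxicity in this test and lower numbers for higher toxicity in this test), compound 1 gives 27200 nM. In this assay compound 2 gives 33900 nM, which is a 1.2-fold higher number from compound 1 to compound 2 (0.10 log units; within the scatter). Compound 3 `COc1ccc(C2CC(c3cc(Cl)c(C)cc3O)=NN2c2ccc(S(N)(=O)=O)cc2)cc1OC` carries the 3,4-dimethoxyphenyl at that position. For compound 3 the result in this assay is only a limit, > 100000 nM. Compound 3 therefore stands at the high end of the numbers shown, without an exact figure, at the limit of > 100000 nM in this assay, at which 1 of the 3 values shown sits. The steps into it were an at least 3.6-fold higher number from compound 1 to compound 3 (0.56 log units; beyond the scatter) and an at least 2.9-fold higher number from compound 2 to compound 3 (0.46 log units; beyond the scatter), both beyond the scatter and both upward. Compound 4 `COc1ccc(C2CC(c3cc(Cl)c(C)cc3O)=NN2c2ccc(S(N)(=O)=O)cc2)c(OC)c1OC` differs from compound 3 by methoxy in place of hydrogen on an aromatic carbon. Since both measured steps towards the dimethoxyphenyl raised the number, a further methoxy on the same ring is expected to leave the number at or past the limit, the expected step being a step that the limit leaves unreadable from compound 3 to compound 4. For compound 4 the estimate in this assay is 150000 nM, with a range from 60000 nM to 400000 nM.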

Compound 4, concentration lethal to 50% of the cells: > 100000 nM
Compound 4: only a limit was reported; the forecaster's own chance of this, stated with the estimate: 75%; the middle value lies beyond the limit too.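

In this assay, the 2,3,4-trimethoxyphenyl at the saturated ring carbon gives a second limit rather than an exact figure: the limit of > 100000 nM in this assay, at which 2 of the 4 values shown sit.

Against the two compounds with exact figures, the change gives an at least 2.9-fold higher number from compound 2 to compound 4 (0.46 log units; beyond the scatter) and an at least 3.6-fold higher number from compound 1 to compound 4 (0.56 log units; beyond the scatter), so a group in the 2-position of this aryl, as in the 2-hydroxyphenyl, the 2-chlorophenyl and the 2,3,4-trimethoxyphenyl, does not alone keep the number measurable. The step for the added methoxy cannot be read, as compound 3 and compound 4 are both limits.

As far as these compounds go, whether a single methoxy, as in 2-methoxyphenyl, would give an exact figure remains open. So does the effect of an amine or a carboxylic acid on this aryl.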